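Pyrrolidin-1-yl in place of isobutylamino

A few compounds are considered here, and "the series" means these few. Any claim that something is new, unique, unknown or untested is made for them only; others in the source may bear on it.

In a functional assay on A549 cells (Homo sapiens) for inhibition, read by sulforhodamine B assay, with a stated time of 72 h (a higher number here means a weaker inhibitor, a lower number a stronger inhibitor), compound 1 `Nc1sc(-c2ccc(Cl)cc2)c(-c2ccc(Cl)cc2)c1C(=O)N1CCOCC1` gives 1870 nM, compound 2 `CC(C)(C)NC(=O)c1c(N)sc(-c2ccc(Cl)cc2)c1-c1ccc(Cl)cc1` gives 8850 nM, and compound 3 `CC(C)CNC(=O)c1c(N)sc(-c2ccc(Cl)cc2)c1-c1ccc(Cl)cc1` gives 21000 nM, the highest number of the three. Compound 4 `Nc1sc(-c2ccc(Cl)cc2)c(-c2ccc(Cl)cc2)c1C(=O)N1CCCC1` differs from compound 3 as follows: pyrrolidin-1-yl in place of isobutylamino on a carbonyl carbon. Among the measured compounds shown here, the closest precedent is the large step of an 11-fold higher number from compound 1 to compound 3 (1.05 log units; beyond the scatter), which runs from a ring on the carbonyl carbon to isobutylamino. The modest step of a 4.7-fold higher number from compound 1 to compound 2 (0.68 log units; beyond the scatter) runs the same way, while a 2.4-fold higher number from compound 2 to compound 3 (0.38 log units; beyond the scatter) is also modest. Only compound 1 shows a ring there, so a clear step towards a lower number, smaller than the precedent, is expected in this assay. The expected change is a 5.3-fold lower number from compound 3 to compound 4 (0.72 log units; beyond the scatter). For compound 4 the estimated value is 4000 nM, with an expected range of 1300 nM to 12000 nM.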

Compound 4, half-maximal inhibitory concentration: 890 nM
The estimate for compound 4 lay 4.5-fold (0.65 log units) above the measured number, outside the stated range (below it).
By their numbers in this assay, from the lowest: compound 4; then compound 1; then compound 2; then compound 3.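

In this assay, the second ring on the carbonyl carbon confirms the gain seen with morpholin-4-yl: a 24-fold lower number from compound 3 to compound 4 (1.37 log units; beyond the scatter) and a 9.9-fold lower number from compound 2 to compound 4 (1.00 log units; beyond the scatter) leave both ring amides with lower numbers than both amides that keep the amide hydrogen, with no compound shown going against this. Within the ring pair, a 2.1-fold lower number from compound 1 to compound 4 (0.32 log units; beyond the scatter) is a smaller change, so pyrrolidin-1-yl and morpholin-4-yl differ far less than either differs from isobutylamino. No measurement here explains these differences.

On these data alone, whether the ring itself or the missing amide hydrogen carries the change remains open, and a diethylamino group would separate the two. Piperidin-1-yl would extend the ring comparison.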